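Acid-bearing pyridyl on the ring amine: expected gain

The source may report more compounds than this note shows. Statements on the series, on what has been measured and on what is new or still open speak of the compounds shown alone.

Compound 1 `Clc1cc(Cl)cc(CO[C@H]2CCCN(Cc3ncco3)[C@H]2c2ccccc2)c1` was run in an assay on isolated protein for activation of cGMP-dependent protein kinase 1 (Homo sapiens), read by ADP-Glo, with stated times of 120 min and 40 min; on this read-out lower numbers stand for an effect already at smaller amounts and higher numbers for an effect only at larger amounts of compound. For compound 1 this assay reports only a limit, > 200000 nM, not a number; compound 1 therefore sits at the limit of > 200000 nM in this assay, at which 1 of the 2 values shown sits. Compound 2 `OC[C@@H](O[C@H]1CCCN(Cc2ncc[nH]2)[C@H]1c1ccccc1)c1cc(Cl)cc(Cl)c1` in this assay gives 7000 nM. Compound 3 `O=C(O)c1ccc(CN2CCC[C@H](OCc3cc(Cl)cc(Cl)c3)[C@@H]2c2ccccc2)cn1` has not yet been measured; it differs from compound 1 by 6-carboxypyridin-3-yl in place of 1,3-oxazol-2-yl on a saturated chain carbon bound to an amine nitrogen in a ring. Among the compounds with values here, no step between measured compounds is available here, so the expected step is set from the change alone: a downward step, beyond the scatter, an at least 6.6-fold lower number from compound 1 to compound 3 (0.82 log units; beyond the scatter). For compound 3 the estimate is 30000 nM, expected to fall between 5000 nM and 200000 nM.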

Compound 3, half-maximal effective concentration: > 200000 nM
Compound 3: no number, only a limit; the forecaster's own chance of this, stated with the estimate: 30%; middle value at least 6.6-fold (0.82 log units) away from the limit.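

No step from compound 1 to compound 3 can be read in this assay, as both compounds give only a limit: the limit of > 200000 nM in this assay, at which 2 of the 3 values shown sit.

As far as these compounds go, whether 6-carboxypyridin-3-yl in place of 1,3-oxazol-2-yl changes the half-maximal effective concentration at all remains open.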